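Quinoline amides: swapping the pyridyl amide for dichlorophenyl

This account rests on a few compounds, and the source may have more. Where it says the series, first, only, none or still open, it means among the compounds named here.

Compound 1 `Cc1cc(N(C)C)nc2ccc(NC(=O)c3ccc(Cl)c(Cl)c3)cc12`: > 50000 nM (a limit of the assay)
Compound 2 `CCN1CCN(c2cc(C)c3cc(NC(=O)c4cccc(F)c4)ccc3n2)CC1`: 24900 nM
Compound 3 `CCN1CCN(c2cc(C)c3cc(NC(=O)c4cccnc4)ccc3n2)CC1`: 10600 nM

The read-out is a functional assay on SK-BR-3 cells (Homo sapiens) for antiproliferative activity, read by MTT assay, with a stated time of 72 h; a higher number here means a weaker inhibitor, a lower number a stronger inhibitor. Compound 3 has the lowest of the two numbers shown; the nearest is compound 2, and the step of a 2.3-fold lower number from compound 2 to compound 3 (0.37 log units; beyond the scatter) is what separates them. For compound 1 only a limit is recorded, the value > 50000 nM being a limit of the assay and not a number (the limit of > 50000 nM in this assay, at which 1 of the 3 values shown sits).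

Compound 4 `CCN1CCN(c2cc(C)c3cc(NC(=O)c4ccc(Cl)c(Cl)c4)ccc3n2)CC1` is not yet measured. Against compound 3 the change is 3,4-dichlorophenyl in place of pyridin-3-yl on a carbonyl carbon. For the measured compounds named here, the one measured step on the same carbonyl carbon, a 2.3-fold lower number from compound 2 to compound 3 (0.37 log units; beyond the scatter), went from 3-fluorophenyl to pyridin-3-yl and lowered the number modestly; compound 4 runs the other way, from pyridin-3-yl back to a substituted phenyl, so a modest rise in the number is the expectation. Compound 1 carries the same 3,4-dichlorophenyl amide on a different core and sits at a limit, which widens the range upwards.

Compound 4 is expected at 30000 nM, with a range from 8000 nM to 100000 nM. The expected step is a 2.8-fold higher number from compound 3 to compound 4 (0.45 log units; beyond the scatter), a worsening, with a fair chance that only a limit is returned.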

Compound 4, half-maximal inhibitory concentration: 2160 nM
Compound 4: middle estimate off by 14-fold (1.14 log units), on the high side; the whole stated range lies above it.
By their numbers in this assay, from the lowest: compound 4; then compound 3; then compound 2. At a limit, above all of these: compound 1.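

In this assay the amide substituent on the carbonyl carbon turns out to be able to lower the number well past what pyridin-3-yl gives: 3,4-dichlorophenyl in place of pyridin-3-yl is (a 4.9-fold lower number from compound 3 to compound 4 (0.69 log units; beyond the scatter)), and in place of 3-fluorophenyl it is larger (a 12-fold lower number from compound 2 to compound 4 (1.06 log units; beyond the scatter)). The earlier step had pointed only from a substituted phenyl to pyridin-3-yl, whereas with compound 4 the two substituted phenyl amides fall on either side of pyridin-3-yl, so the ring type alone does not set the order among compound 2, compound 3 and compound 4. With the 3,4-dichlorophenyl amide held constant, 4-ethylpiperazin-1-yl in place of dimethylamino on the aromatic carbon also matters (an at least 23-fold lower number from compound 1 to compound 4 (1.36 log units; beyond the scatter)), though that step starts from a limit and not from a number: the limit of > 50000 nM in this assay, at which 1 of the 4 values shown sits.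

The compounds shown do not separate the contribution of each chlorine, which a 3-chlorophenyl or 4-chlorophenyl amide would address. Also open, from the compounds shown here alone, is how far the amine position tolerates change, for example a morpholine or a piperazine carrying a longer chain in place of 4-ethylpiperazin-1-yl.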